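Phenylsulfonyl for thiophene carbonyl: a cytotoxicity outlook

This account rests on a few compounds, and the source may have more. Where it says the series, first, only, none or still open, it means among the compounds named here.

Measured so far:
compound 1 `CN(C(=O)c1ccccc1)c1ccc(C(O)(C(F)(F)F)C(F)(F)F)cc1` gives 65000 nM in an ADME assay on Li23 cells (Homo sapiens) for cytotoxicity, read by WST assay; a lower number here means that less compound is tolerated, a higher number that more compound is tolerated
compound 2 `CN(C(=O)c1ccsc1)c1ccc(C(O)(C(F)(F)F)C(F)(F)F)cc1` gives 44000 nM in this assay

Among the measured compounds shown here, compound 2 holds the lower of the two numbers, but its only neighbour is compound 1, and the step of a 1.5-fold lower number from compound 1 to compound 2 (0.17 log units; within the scatter) lies within the scatter, so the two cannot be ordered. Compound 3 `CN(c1ccc(C(O)(C(F)(F)F)C(F)(F)F)cc1)S(=O)(=O)c1ccccc1` takes the change (phenylsulfonyl in place of (thiophen-3-yl)carbonyl on a nitrogen on an aromatic ring). For the measured compounds named here, the one measured step, a 1.5-fold lower number from compound 1 to compound 2 (0.17 log units; within the scatter), exchanges the aryl group on the carbonyl carbon and was within the scatter; no measured step replaces the carbonyl itself by a sulfonyl, so that part of the change is untested. On this basis no step beyond the scatter is expected in this assay, though the wider range reflects the untested part. Compound 3 is expected to give 50000 nM, between 18000 nM and 140000 nM. The expected step is a 1.1-fold higher number from compound 2 to compound 3 (0.06 log units; within the scatter).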

Compound 3, half-maximal cytotoxic concentration: 16000 nM
Compound 3: middle estimate off by 3.1-fold (0.49 log units), on the high side, and the stated range ends above it.
By their numbers in this assay, from the lowest: compound 3; then compounds 2 and 1 (each within the scatter of the next).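

Replacing the carbonyl with a sulfonyl on this nitrogen moves the number in this assay beyond the scatter, with phenylsulfonyl in place of (thiophen-3-yl)carbonyl giving a 2.8-fold lower number from compound 2 to compound 3 (0.44 log units; beyond the scatter) and phenylsulfonyl in place of benzoyl giving a 4.1-fold lower number from compound 1 to compound 3 (0.61 log units; beyond the scatter). Both steps are modest and run the same way, so less compound is tolerated with phenylsulfonyl than with either carbonyl group, whereas the aryl exchange on the carbonyl carbon, a 1.5-fold lower number from compound 1 to compound 2 (0.17 log units; within the scatter), stayed within the scatter. Nothing available here accounts for the difference.

Going by these compounds, it remains open whether the lower number would persist with a thiophen-3-ylsulfonyl or a methylsulfonyl group on this nitrogen. The compounds shown also leave open how a urea or a simple benzyl amine at this place would compare in this assay.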